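A few compounds are considered here, and "the series" means these few. Any claim that something is new, unique, unknown or untested is made for them only; others in the source may bear on it.

Of the compounds shown here, three built on one shared core have been tested in a functional assay on PANC-1 cells (Homo sapiens) for inhibition, read by MTT assay, with a stated time of 24 h, tested at 10 uM; a higher number here means more inhibition at the concentration tested (going by the name of the read-out), a lower number less inhibition. Compound 1, with the structure `COc1ccc(NC(=O)Oc2cc(=O)n(CCCO)c3c2CC(CC=C(C)C)C(C)(C)C3)cc1`, gives 3.7% in this assay. Compound 2, with the structure `COc1cccc(NC(=O)Oc2cc(=O)n(CCCO)c3c2CC(CC=C(C)C)C(C)(C)C3)c1`, gives 16.2%. The two differ in one place only, namely (3-methoxyphenyl in place of 4-methoxyphenyl on an amide-type nitrogen), and that change gave a step of a number 12.5 percentage points higher from compound 1 to compound 2 (beyond the scatter). Compound 3, with the structure `COc1ccc(NC(=O)Oc2cc(=O)n(CCCO)c3c2CC(C/C=C(\C)CCC=C(C)C)C(C)(C)C3)cc1`, gives 64.1%; it differs from compound 1 by 3-methylbut-2-en-1-yl in place of hydrogen on a saturated chain carbon bound to a double-bonded chain carbon, a change that produced a step of a number 60.4 percentage points higher from compound 1 to compound 3 (beyond the scatter) and leaves compound 3 standing above both of the others beyond the scatter.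

Compound 4, with the structure `COc1cccc(NC(=O)Oc2cc(=O)n(CCCO)c3c2CC(C/C=C(\C)CCC=C(C)C)C(C)(C)C3)c1`, has not yet been measured. It differs from compound 3 by 3-methoxyphenyl in place of 4-methoxyphenyl on an amide-type nitrogen, the same change, at the same place, that turned compound 1 into compound 2, while its core differs from the core of compound 1 by 3-methylbut-2-en-1-yl in place of hydrogen on a saturated chain carbon bound to a double-bonded chain carbon. Because that change gave a number 12.5 percentage points higher from compound 1 to compound 2 (beyond the scatter), a step of about a number 9.9 percentage points higher from compound 3 to compound 4 (within the scatter) is expected here too. Compound 4 is therefore expected to give roughly 74% in this assay, most likely between 55% and 90%.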

Compound 4, a percentage reported as inhibition, at one concentration (the size of the read-out at that concentration, not a potency): 47%
Estimate against measurement, compound 4: 27 percentage points above; measured number below the stated range.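

In this assay, putting 3-methoxyphenyl in place of 4-methoxyphenyl on the amide-type nitrogen gave a number 17.1 percentage points lower from compound 3 to compound 4 (beyond the scatter), so this change did not carry over from one core to the other, even in direction: the same change on two cores in this assay, a number 12.5 percentage points higher (beyond the scatter) from compound 1 to compound 2 and a number 17.1 percentage points lower (beyond the scatter) from compound 3 to compound 4, 29.6 percentage points apart, beyond the scatter of two such steps

Adding 3-methylbut-2-en-1-yl to the chain gave a number 30.8 percentage points higher from compound 2 to compound 4 (beyond the scatter), so that change raised the number on both compounds tested, but by clearly different amounts: the same change on two cores in this assay, a number 60.4 percentage points higher (beyond the scatter) from compound 1 to compound 3 and a number 30.8 percentage points higher (beyond the scatter) from compound 2 to compound 4, 29.6 percentage points apart, beyond the scatter of two such steps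

Among the compounds shown here, the two changes therefore do not add up independently in these four compounds, but the data do not show why, and with only two cores they cannot show whether the reversal would recur on any other core.

The compounds shown leave open how a plain phenyl or a pyridyl group on the amide-type nitrogen would behave on either core. They also leave open whether a chain longer than that of compound 3 would raise the number further or lower it.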